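From Cyclobutyl to Oxolanyl on the Ring Amine

The source may report more compounds than this note shows. Statements on the series, on what has been measured and on what is new or still open speak of the compounds shown alone.

Compound 3 `Fc1cccc(C#Cc2nc3c(s2)CN(C2CCC2)CC3)c1` stands at a limit. In an assay on HEK293 cells for positive allosteric modulation of metabotropic glutamate receptor 5 (Homo sapiens), read by FLIPR, with a stated time of 1 h (a lower number here means that less compound is needed, a higher number that more compound is needed for the effect), compound 3 gives > 10000 nM, which is a limit of the assay and not a number. Compound 1 `CN1CCc2nc(C#Cc3cccc(F)c3)sc2C1` likewise returns a limit, > 10000 nM in this assay. The step that the two limits leave unreadable from compound 1 to compound 3 therefore cannot be read, because both of its ends sit at the limit of > 10000 nM in this assay, at which 2 of the 3 values shown sit. Within the data shown here, compound 2 `CCCCN1CCc2nc(C#Cc3ccccc3)sc2C1` differs from compound 3 in more than one place, so no single step connects them; in this assay compound 2 gives 110 nM, a number rather than a limit.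

Compound 4 `Fc1cccc(C#Cc2nc3c(s2)CN(C2CCOC2)CC3)c1` is the compound still to be measured. Its change from compound 3 is oxolan-3-yl in place of cyclobutyl on an amine nitrogen in a ring. Among the measured compounds shown here, no measured step bears directly on this change: the one step among the measured compounds is unreadable and also concerns a different group. The expectation for compound 4 can therefore rest only on where compound 3 stands, at the limit. Compound 4 is expected to stay near that limit, with a number no higher from compound 3 to compound 4 (the limit leaves the size open) as the expected step in this assay. The estimate for compound 4 in this assay is 10000 nM, with an expected range from 2000 nM to 40000 nM.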

Compound 4, half-maximal effective concentration: > 10000 nM
Compound 4: only a limit was reported; the forecaster's own chance of this, stated with the estimate: 65%; the middle value lies on the limit itself.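

In this assay compound 4 gives > 10000 nM, a limit of the assay and not a number. Compound 1 and compound 3 also stand at limits, so no step to compound 4 can be read: the limit of > 10000 nM in this assay, at which 3 of the 4 values shown sit.

The compounds shown leave open whether oxolan-3-yl, cyclobutyl and methyl on the amine nitrogen in a ring differ at all in this assay.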